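Testing a Nitrile on a Shared Fused Core

A few compounds are considered here, and "the series" means these few. Any claim that something is new, unique, unknown or untested is made for them only; others in the source may bear on it.

Among the measured compounds shown here, compound 1 `CN(C(=O)c1ccccc1)c1ccc2[nH]c(-c3n[nH]c4ccccc34)cc2n1` is one of two compounds measured in a functional assay on SMMC-7721 cells (Homo sapiens) for antiproliferative activity, read by MTT assay, with a stated time of 72 h; on this read-out higher numbers stand for weaker inhibition and lower numbers for stronger inhibition; in this assay compound 1 gives 12500 nM. Its partner, compound 2 `COc1cccc(C(=O)N(C)c2ccc3[nH]c(-c4n[nH]c5ccccc45)cc3n2)c1`, differs by a methoxy in place of hydrogen on an aromatic carbon, and in this assay compound 2 gives 22000 nM, so that the step of a 1.8-fold higher number from compound 1 to compound 2 (0.25 log units; within the scatter) sits within the scatter and the two numbers cannot be ordered.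

Compound 3 `CN(C(=O)c1ccccc1)c1ccc2[nH]c(-c3n[nH]c4cc(C#N)ccc34)cc2n1` has not been measured. Its change from compound 1 is cyano in place of hydrogen on an aromatic carbon. For the measured compounds named here, no measured step touches that ring or that group; the only step available, from compound 1 to compound 2, was a small substituent change elsewhere and stayed within the scatter. With nothing pointing either way, the expectation for compound 3 is a step of no change at the digits printed from compound 1 to compound 3 (within the scatter), that is, none beyond the scatter. The estimated value for compound 3 in this assay is therefore 12500 nM, with a range from 5000 nM to 30000 nM.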

Compound 3, half-maximal inhibitory concentration: > 50000 nM
Compound 3: no number, only a limit; the forecaster's own chance of this, stated with the estimate: 5%; at least 4.0-fold (0.60 log units) between middle value and limit.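

In this assay, among the compounds shown here, cyano in place of hydrogen on an aromatic carbon gives an at least 4.0-fold higher number from compound 1 to compound 3 (0.60 log units; beyond the scatter) and is the first step here to pass beyond the scatter. For the compounds shown here, the only earlier step, a 1.8-fold higher number from compound 1 to compound 2 (0.25 log units; within the scatter) and made in another part of the molecule, stayed within the scatter and said nothing about this six-membered aromatic ring of carbon only, which now appears sensitive to a single change. Compound 3 gives > 50000 nM as a limit of the assay and not as a number: the limit of > 50000 nM in this assay, at which 1 of the 3 values shown sits.

The compounds shown leave open whether weaker inhibition follows from the nitrile itself or from any group placed here, which an amine or a carboxylic acid at this place would help to separate. From the compounds shown here alone, how far the true value of compound 3 lies past the limit also remains unknown.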